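The compounds below may be only part of what the source reports. "The series", "measured", "known", "first", "only" and "open" are said of these compounds alone.

Series notes. Compound 1 `O=C(C1=C(OC2CCCCC2)C(=O)N(CCCn2ccnc2)C1c1ccc(Br)cc1)c1ccccc1` is the reference of the set: in a functional assay on U2OS cells (Homo sapiens) for antiproliferative activity, read by MTT assay, with a stated time of 72 h (a higher number here means a weaker inhibitor, a lower number a stronger inhibitor), compound 1 gives 22400 nM. Compound 2 `O=C(C1=C(Nc2ccc(F)cc2)C(=O)N(CCCn2ccnc2)C1c1ccc(Br)cc1)c1ccccc1` keeps the shared core of compound 1 and carries the (4-fluorophenyl)amino group on the double-bonded ring carbon; in this assay compound 2 gives 30000 nM. For the measured compounds named here, the single step between them, a 1.3-fold higher number from compound 1 to compound 2 (0.13 log units; within the scatter), is within the scatter, so compound 2 stands alongside compound 1, the only other measured compound, with no separation between the two numbers.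

Compound 3 `O=C(C1=C(Nc2ccc(I)cc2)C(=O)N(CCCn2ccnc2)C1c1ccc(Br)cc1)c1ccccc1` differs from compound 2 by iodo in place of fluoro on an aromatic carbon. Going by the values given here, no measured step bears on this change: the only step in hand, a 1.3-fold higher number from compound 1 to compound 2 (0.13 log units; within the scatter), swaps the whole group on the double-bonded ring carbon and was itself within the scatter, and no pair differing only in the halogen on the (4-fluorophenyl)amino ring has been measured. No step beyond the scatter is therefore expected in this assay, in either direction. Compound 3 is estimated at 30000 nM in this assay, within a range of 12000 nM to 75000 nM, which corresponds to an expected step of no change at the digits printed from compound 2 to compound 3 (within the scatter).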

Compound 3, half-maximal inhibitory concentration: 12000 nM
Beside the measured number, compound 3's estimate is 2.5-fold (0.40 log units) above it; measured number inside the range.
By their numbers in this assay, from the lowest: compounds 3, 1 and 2 (each within the scatter of the next, the first and the last beyond it).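

Within this assay, the halogen on the aromatic carbon para to a large group gives the first step in the series that lies beyond the scatter, a 2.5-fold lower number from compound 2 to compound 3 (0.40 log units; beyond the scatter), though it is modest; the earlier step, which exchanged the whole group on the double-bonded ring carbon, did not show that this site could separate two compounds. The comparison with the reference, a 1.9-fold lower number from compound 1 to compound 3 (0.27 log units; within the scatter), stays within the scatter, so iodo separates compound 3 from compound 2 but (4-iodophenyl)amino in place of cyclohexyloxy does not separate compound 3 from compound 1. No measurement in hand gives a reason for the step from fluoro to iodo.

As far as these compounds go, it remains open whether this step belongs to iodo alone or is shared by chloro or bromo on the same aromatic carbon, or by a methyl or methoxy group there. One matched pair also cannot show whether the step would hold with another group elsewhere on the shared core, such as a carboxylic acid in place of the bromo.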